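A few compounds are considered here, and "the series" means these few. Any claim that something is new, unique, unknown or untested is made for them only; others in the source may bear on it.

In a functional assay on HCT-15 cells (Homo sapiens) for antiproliferative activity, read by XTT assay (a lower number here means a stronger inhibitor, a higher number a weaker inhibitor), compound 2 `CC(C)COc1cccc2occ(Cc3coc4ccccc4c3=O)c(=O)c12` gives > 10000 nM, which is a limit of the assay and not a number. Its standing is therefore known only as the limit of > 10000 nM in this assay, at which 1 of the 2 values shown sits. Going by the values given here, the sole numerical reading comes from compound 1 `O=c1c(Cc2coc3cccc(OCC4CCCCC4)c3c2=O)coc2ccccc12`, which gives 4240 nM in this assay.

Compound 3 `CC(C)CCOc1cccc2occ(Cc3coc4ccccc4c3=O)c(=O)c12` differs from compound 2 by isobutyl in place of isopropyl on a saturated chain carbon bound to an oxygen on an aromatic ring. Among the compounds with values here, only one measured step bears on this change at the same place: an at least 2.3-fold higher number from compound 1 to compound 2 (0.37 log units; beyond the scatter), with isopropyl in place of cyclohexyl. That step has only a lower bound on its size, so it gives direction more firmly than magnitude.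

On the strength of that step, the isobutyl of compound 3 is expected to move the number modestly back toward compound 1, although a second reading at the limit remains quite possible. The expected step is an at least 1.3-fold lower number from compound 2 to compound 3 (0.12 log units; that floor lies within the scatter). For compound 3 the estimated value is 7500 nM, with an expected range from 3500 nM to 16000 nM.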

Compound 3, half-maximal inhibitory concentration: > 10000 nM
Compound 3: no number, only a limit (the forecaster's own chance of this, stated with the estimate: 45%); middle value at least 1.3-fold (0.12 log units) away from the limit.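

In this assay, lengthening isopropyl to isobutyl on a saturated chain carbon bound to an oxygen on an aromatic ring brings no number back: compound 3 gives > 10000 nM, which is a limit of the assay and not a number. Isobutyl in place of cyclohexyl gives an at least 2.3-fold higher number from compound 1 to compound 3 (0.37 log units; beyond the scatter), so a second open chain joins isopropyl without a numerical reading. Going by these compounds alone, compound 1, at 4240 nM, remains the only numerical reading at this position. The step between the two limits cannot be read, so the extra carbon of isobutyl has no measurable size here, and the series now stands at: the limit of > 10000 nM in this assay, at which 2 of the 3 values shown sit.

As far as these compounds go, how far compound 2 and compound 3 lie beyond the limit stays open, as does whether the ring of cyclohexyl or its carbon count goes with the measurable value. Cyclopentyl, benzyl or an open chain longer than isobutyl at this place would separate those two readings.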